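Swapping a two-ring carbon group for a methylcyclohexyl

The compounds below may be only part of what the source reports. "The series", "measured", "known", "first", "only" and "open" are said of these compounds alone.

Of the compounds shown here, two sharing one core have so far been tested in an ADME assay on a cell-free system (plasma, Rattus norvegicus) for protein binding. Compound 1 `O=C(C1CCC(F)(F)CC1)N1CC(c2nc(-c3cccc(Cl)c3)no2)C1` gives 96.9%. Compound 2 `O=C([C@H]1CC2CCC1C2)N1CC(c2nc(-c3cccc(F)c3)no2)C1` gives 99.2%, which is the lowest unbound fraction of the two; the nearest is compound 1, whose unbound fraction is beyond the scatter higher. Compound 3 `CC1CCCCC1C(=O)N1CC(c2nc(-c3cccc(F)c3)no2)C1` is the next to be measured. It differs from compound 2 in one place, on a carbonyl carbon: a group of 7 heavy atoms (7 carbon; one six-membered non-aromatic ring of carbon only) in place of a group of 7 heavy atoms (7 carbon; 2 five-membered non-aromatic rings of carbon only), on a carbonyl carbon. The group that leaves and the group that enters have the same count of heavy atoms and the same absence of donors and acceptors, so only the ring arrangement changes. For the measured compounds named here, no measured pair shows the effect of this kind of swap, so the step from compound 2 to compound 3 in this assay is expected to be small, at most a slight move toward lower binding, and likely within the scatter: a 1.5-fold higher unbound fraction from compound 2 to compound 3 (0.18 log units; within the scatter). Compound 3 is therefore expected to give about 98.8%, with a range from 97.3% to 99.5%.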

Compound 3, plasma protein binding: 94.5%
Beside the measured number, compound 3's estimate is 4.6-fold (0.66 log units) (unbound fraction) below it, and the stated range ends above it.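

In this assay the place on the carbonyl carbon proves sensitive to the carbon framework alone: the change to 2-methylcyclohexyl gives a 6.9-fold higher unbound fraction from compound 2 to compound 3 (0.84 log units; beyond the scatter) even though the group that leaves and the group that enters have the same count of heavy atoms and neither carries a hydrogen-bond donor or acceptor. Compound 1 and compound 2 differ in more than one place, so they could not isolate this change. No measurement offered here explains the size of this step.

This single pair cannot show whether the methyl group, the single six-membered ring or the loss of the two-ring framework matters most. It also leaves open how this place would respond to a group containing an amine or a carboxylic acid, or to a longer chain.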